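The source may report more compounds than this note shows. Statements on the series, on what has been measured and on what is new or still open speak of the compounds shown alone.

Compound 1 `Cc1ccc(S(=O)(=O)NC(=N)N2CCN(c3cc4c(cc3F)c(=O)c(C(=O)O)cn4C3CC3)CC2)cc1` gives 71 nM
Compound 2 `CCn1cc(C(=O)O)c(=O)c2cc(F)c(N3CCN(C(=N)NS(=O)(=O)c4ccc(Cl)cc4)CC3)cc21` gives 71 nM

Both values come from a functional assay on A549 cells (Homo sapiens) for antiproliferative activity, read by MTT assay, with a stated time of 72 h (on this read-out higher numbers stand for weaker inhibition and lower numbers for stronger inhibition), and on these numbers compound 2 stands level with compound 1. Compound 3 `CCn1cc(C(=O)O)c(=O)c2cc(F)c(N3CCN(C(=N)NS(=O)(=O)c4ccc(C)cc4)CC3)cc21` differs from compound 2 by a single change methyl in place of chloro on an aromatic carbon, para to a large group. For the measured compounds named here, no measured pair shows this change alone. Compound 1 also carries the 4-methylphenyl group and gives 71 nM here, so no step beyond the usual scatter is expected in this assay. The expected change is a 1.1-fold higher number from compound 2 to compound 3 (0.02 log units; within the scatter) and it should stay small. For compound 3 the estimated value is 75 nM, with an expected range from 30 nM to 190 nM.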

Compound 3, half-maximal inhibitory concentration: 71 nM
For compound 3 the middle estimate is 1.1-fold (0.02 log units) above the measured one; measured number inside the range.
By their numbers in this assay, from the lowest: compounds 1, 2 and 3 (each within the scatter of the next).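

Exchanging 4-chlorophenyl for 4-methylphenyl gives no change at the digits printed from compound 2 to compound 3 (within the scatter) in this assay, so both groups are accepted at this aromatic carbon. Ethyl in place of cyclopropyl on the aromatic nitrogen gives no change at the digits printed from compound 1 to compound 3 (within the scatter) on the same read-out, which is the first direct comparison of those two groups among these compounds. Going by these compounds, whether an amine, a methoxy group or a longer chain at that aromatic carbon would hold the number stays open. The data at hand also offer no explanation for the unchanged values.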